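Sulfonyl aryl variation on a shared chromone core: notes

The source may report more compounds than this note shows. Statements on the series, on what has been measured and on what is new or still open speak of the compounds shown alone.

Measured compounds in a functional assay on SUP-B15 cells (Homo sapiens) for antiproliferative activity, with a stated time of 72 h; a lower number here means that less compound is needed, a higher number that more compound is needed for the effect:
- compound 1 `COc1ccc(-c2cc(=O)c3c(OC)cc(OC)cc3n2S(=O)(=O)c2cccc([N+](=O)[O-])c2)cc1` gives > 39600 nM, a limit of the assay.
- compound 2 `COc1ccc(-c2cc(=O)c3c(OC)cc(OC)cc3n2S(=O)(=O)c2ccc(C)c([N+](=O)[O-])c2)cc1` gives > 51700 nM, a limit of the assay.
- compound 3 `COc1ccc(-c2cc(=O)c3c(OC)cc(OC)cc3n2S(=O)(=O)c2ccc(F)cc2)cc1` gives > 65500 nM, a limit of the assay.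

Going by the values given here, compound 3 stands at a limit in this assay, and the two other values shown are limits as well, so no compound here has a numerical potency. The step from compound 1 to compound 2, a methyl in place of hydrogen on an aromatic carbon, is a step that the two limits leave unreadable from compound 1 to compound 2. The step from compound 1 to compound 3 is a step that the two limits leave unreadable from compound 1 to compound 3, and that from compound 2 to compound 3 is a step that the two limits leave unreadable from compound 2 to compound 3. All three values sit at limits, as in the limit of > 39600 nM in this assay, at which 1 of the 3 values shown sits, the limit of > 51700 nM in this assay, at which 1 of the 3 values shown sits, and (the limit of > 65500 nM in this assay, at which 1 of the 3 values shown sits).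

Compound 4 `COc1ccc(-c2cc(=O)c3c(OC)cc(OC)cc3n2S(=O)(=O)c2cc(F)c(F)c(F)c2)cc1` differs from compound 3 by 3,4,5-trifluorophenyl in place of 4-fluorophenyl on a sulfonyl sulfur. Every measured step bears on a change at the same sulfonyl sulfur, yet none of them is readable in size because of the limits in the limit of > 39600 nM in this assay, at which 1 of the 3 values shown sits, the limit of > 51700 nM in this assay, at which 1 of the 3 values shown sits, and (the limit of > 65500 nM in this assay, at which 1 of the 3 values shown sits). The expected step from compound 3 to compound 4 in this assay is therefore a step that the limit leaves unreadable from compound 3 to compound 4, with no direction supported.

For compound 4 the estimate in this assay is 80000 nM, ranging from 30000 nM to 300000 nM, and the most likely outcome is again a limit.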

Compound 4, half-maximal effective concentration: > 65500 nM
Compound 4: a limit, no number; the forecaster's own chance of this, stated with the estimate: 85%; the middle value does not contradict the limit.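

In this assay compound 4 gives > 65500 nM, a limit of the assay and not a number, so its steps from compound 1, compound 2 and compound 3 cannot be read in size. The compounds shown leave open how these four aryl groups on the sulfonyl sulfur rank against one another, since none has a numerical potency.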